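Chloro on the phenyl of a thiourea analogue

The source may report more compounds than this note shows. Statements on the series, on what has been measured and on what is new or still open speak of the compounds shown alone.

Compound 3 `COc1cc(/C=C/C(=O)C2=C(/C=C/c3ccc(O)c(OC)c3)NC(=S)NC2c2ccccc2)ccc1O` gives 50.4% in a functional assay, with a stated time of 20 min, tested at 50 uM; on this read-out higher numbers stand for a stronger effect at the one concentration tested and lower numbers for a weaker effect. Among the three measured compounds it stands second highest: compound 1 `COc1cc(/C=C/C(=O)C2=C(/C=C/c3ccc(O)c(OC)c3)NC(=O)NC2c2ccccc2)ccc1O` gives 50.2%, which lies within the scatter of compound 3, while compound 2 `COc1cc(/C=C/C(=O)C2=C(/C=C/c3ccc(O)c(OC)c3)NC(=O)NC2c2ccc(N(C)C)cc2)ccc1O` gives 89.2%, well above both. Compound 4 `COc1cc(/C=C/C(=O)C2=C(/C=C/c3ccc(O)c(OC)c3)NC(=S)NC2c2ccccc2Cl)ccc1O` differs from compound 3 by one change: chloro in place of hydrogen on an aromatic carbon. Going by the values given here, no measured step covers a chloro; the only step known, a number 39 percentage points higher from compound 1 to compound 2 (beyond the scatter), concerns a dimethylamino in place of hydrogen on an aromatic carbon of the same phenyl, a different group at a different place, so it cannot be carried over. Compound 4 is therefore expected to stay close to compound 3, with a step of a number 1.6 percentage points higher from compound 3 to compound 4 (within the scatter) that stays within the scatter. Compound 4 is estimated at 52%, between 35% and 70%.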

Compound 4, a percentage reported as activity, at one concentration (the size of the read-out at that concentration, not a potency): 55.6%
Compound 4: the middle estimate sits 3.6 percentage points below what was measured; low and high end bracket the measured number.
By their numbers in this assay, from the lowest: compounds 1, 3 and 4 (each within the scatter of the next); then compound 2.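

In this assay, a chloro on an aromatic carbon ortho to a large group, the change from phenyl to 2-chlorophenyl, gives a number 5.2 percentage points higher from compound 3 to compound 4 (within the scatter) and so shows no effect that can be told from scatter. Going by these compounds alone, this is the first reading at this position, and it shows that a single chlorine atom can be placed there without a clear change in the read-out. Nothing measured here bears on the reason for this result. From the compounds shown here alone, whether an amine or a carboxylic acid on this same carbon would move the number stays open. So does whether a chloro on another carbon of the ring would read the same.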